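The source may hold more compounds than are shown below. What is called first, only, known or untested is meant among the compounds shown, and "the series" means these compounds.

Series notes, three measured compounds and one to come. Compound 1 `CCN1CCC(CNC(=O)c2cc(-c3ccc(NS(=O)(=O)c4cccc(Cl)c4Cl)cc3)nc3[nH]ncc23)C1` gives 109 nM in an assay for inhibition of serine/threonine-protein kinase Sgk1 (Homo sapiens), with stated times of 30 min and 60 min, in the presence of a further agent that is not named here; a lower number here means a stronger inhibitor, a higher number a weaker inhibitor. Compound 2 `CCOc1nc(-c2ccc(NS(=O)(=O)c3cc(Cl)ccc3F)cc2)nc2[nH]nc(C)c12` gives 183 nM in this assay. For the measured compounds named here, compound 3 `Cc1n[nH]c2nc(-c3ccc(NS(=O)(=O)c4cc(Cl)ccc4F)cc3)nc(OCCC(=O)N(C)C)c12` gives 438 nM in this assay, the highest number of the three; the only single step within the measured set, a 2.4-fold higher number from compound 2 to compound 3 (0.38 log units; beyond the scatter), shows that the larger chain on the ring oxygen is carried at a cost.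

Compound 4 `Cc1n[nH]c2nc(-c3ccc(NS(=O)(=O)c4cc(Cl)ccc4F)cc3)nc(OCC3(CN)COC3)c12` differs from compound 3 by 3-(aminomethyl)oxetan-3-yl in place of (dimethylcarbamoyl)methyl on a saturated chain carbon bound to an oxygen on an aromatic ring. Going by the values given here, no measured pair mirrors this exchange; the step from compound 2 to compound 3 is the only one that touches the same position, and it shows the chain itself is tolerated. Compound 1, with a chain amine, gives a lower number than compound 3, but its core and sulfonamide differ, so it guides only loosely. The expectation for compound 4 is therefore a step no larger than the scatter, a 1.4-fold lower number from compound 3 to compound 4 (0.14 log units; within the scatter), leaning slightly toward a lower number. Compound 4 is estimated at 320 nM, in the range 110 nM to 950 nM.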

Compound 4, half-maximal inhibitory concentration: 1 nM
For compound 4 the middle estimate is 320-fold (2.51 log units) above the measured one, and the stated range ends above it.
By their numbers in this assay, from the lowest: compound 4; then compounds 1 and 2 (each within the scatter of the next); then compound 3.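

In this assay, for the compounds shown here, the group on the saturated chain carbon bound to the ring oxygen matters far more than the earlier compounds suggested: the same atoms, joined differently, give a 440-fold lower number from compound 3 to compound 4 (2.64 log units; beyond the scatter) on the shared core. Set against ethoxy, the new chain gives a 180-fold lower number from compound 2 to compound 4 (2.26 log units; beyond the scatter) in the opposite direction to a 2.4-fold higher number from compound 2 to compound 3 (0.38 log units; beyond the scatter) so a larger chain is not a cost in itself, and what it carries decides the outcome. Nothing measured here gives a reason for this gain.

The compounds shown do not separate the contribution of the aminomethyl from that of the oxetane ring. A hydroxymethyl in place of the aminomethyl, or a plain aminoalkyl chain without the ring, would put each part to the test on its own.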